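Iodo in place of bromo, tried a second time

The compounds below may be only part of what the source reports. "The series", "measured", "known", "first", "only" and "open" are said of these compounds alone.

Three compounds have been measured in a functional assay on L1210 cells (Mus musculus) for cytotoxicity; a higher number here means a weaker inhibitor, a lower number a stronger inhibitor:

- compound 1 `C=C1C(n2cc(Br)c(=O)[nH]c2=O)O[C@H](CO)[C@@H]1O`: > 100 ug/mL, a limit of the assay
- compound 2 `C=C1C(n2cc(I)c(=O)[nH]c2=O)O[C@H](CO)[C@@H]1O`: > 100 ug/mL, a limit of the assay
- compound 3 `C=C1C(n2cc(Br)c(N)nc2=O)O[C@H](CO)[C@@H]1O`: > 100 ug/mL, a limit of the assay

From compound 1 to compound 2 the change is iodo in place of bromo on an aromatic carbon, and the step is a step that the two limits leave unreadable from compound 1 to compound 2. Compound 4 `C=C1C(n2cc(I)c(N)nc2=O)O[C@H](CO)[C@@H]1O` is made from compound 3 by the same kind of change, (iodo in place of bromo on an aromatic carbon); around the place, the change in compound 4 sits ortho to an amino group (1 heavy atom), whereas in compound 2 it sits ortho to a group of 1 heavy atom. The difference between the two cores is not broken down here.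

Because (the limit of > 100 ug/mL in this assay, at which 3 of the 3 values shown sit), the step from compound 3 to compound 4 is expected to be a step that the limit leaves unreadable from compound 3 to compound 4 in this assay. Compound 4 is thus estimated at 150 ug/mL, most likely reported again only as a limit.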

Compound 4, half-maximal inhibitory concentration: > 100 ug/mL
Compound 4: a limit, no number; the forecaster's own chance of this, stated with the estimate: 85%; the middle value does not contradict the limit.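

Compound 3 and compound 4 both stand only as limits, so no step between them can be read: the limit of > 100 ug/mL in this assay, at which 4 of the 4 values shown sit.

Left open is how strongly any of these compounds acts in this assay, and whether iodo and bromo differ there at all.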